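This account rests on a few compounds, and the source may have more. Where it says the series, first, only, none or still open, it means among the compounds named here.

Working notes on a small series tested in a functional assay on HeLa cells (Homo sapiens) for antiproliferative activity, read by sulforhodamine B assay, with a stated time of 48 h; a higher number here means a weaker inhibitor of growth, a lower number a stronger inhibitor of growth. Compound 2 `Nc1nnc(SC[C@H]2O[C@@H](OCc3noc(-c4ccc([N+](=O)[O-])cc4)n3)[C@@H]3OC4(CCCC4)O[C@@H]32)s1` gives 28000 nM. Compound 1 `Nc1nnc(SC[C@H]2O[C@@H](OCc3noc(-c4ccc(Cl)cc4)n3)[C@@H]3OC4(CCCC4)O[C@@H]32)s1` gives 16000 nM; it differs from compound 2 by chloro in place of nitro on an aromatic carbon, and the step is a 1.8-fold lower number from compound 2 to compound 1 (0.24 log units; within the scatter). Compound 3 `O=[N+]([O-])c1ccc(-c2nc(CO[C@@H]3O[C@H](CSc4ncn[nH]4)[C@H]4OC5(CCCC5)O[C@@H]34)no2)cc1` gives 20000 nM; its core differs from that of compound 2 by 1H-1,2,4-triazol-5-yl in place of 5-amino-1,3,4-thiadiazol-2-yl on a sulfur, and the step is a 1.4-fold lower number from compound 2 to compound 3 (0.15 log units; within the scatter). Compound 4 `Clc1ccc(-c2nc(CO[C@@H]3O[C@H](CSc4ncn[nH]4)[C@H]4OC5(CCCC5)O[C@@H]34)no2)cc1` has not yet been measured in this assay. It differs from compound 3 by chloro in place of nitro on an aromatic carbon, the same change as from compound 2 to compound 1, at the same place. Among the measured compounds shown here, the step from compound 3 to compound 4 is expected to be a 1.7-fold lower number from compound 3 to compound 4 (0.22 log units; within the scatter) because a 1.8-fold lower number from compound 2 to compound 1 (0.24 log units; within the scatter) is the only measured instance of this change and stayed within the scatter. Compound 4 is accordingly estimated at 12000 nM, between 6000 nM and 28000 nM.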

Compound 4, concentration for 50% growth inhibition: 14000 nM
Compound 4: middle estimate off by 1.2-fold (0.07 log units), on the low side; the measured number falls inside the stated range.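

In this assay, chloro in place of nitro on an aromatic carbon gives a 1.4-fold lower number from compound 3 to compound 4 (0.15 log units; within the scatter), and this step agrees with the earlier one on the other core: the same change on two cores in this assay, a 1.8-fold lower number (0.24 log units; within the scatter) from compound 2 to compound 1 and a 1.4-fold lower number (0.15 log units; within the scatter) from compound 3 to compound 4, 1.2-fold (0.09 log units) apart, within the scatter of two such steps. 1H-1,2,4-triazol-5-yl in place of 5-amino-1,3,4-thiadiazol-2-yl on a sulfur gives a 1.1-fold lower number from compound 1 to compound 4 (0.06 log units; within the scatter), and this step also agrees with its earlier counterpart: the same change on two cores in this assay, a 1.4-fold lower number (0.15 log units; within the scatter) from compound 2 to compound 3 and a 1.1-fold lower number (0.06 log units; within the scatter) from compound 1 to compound 4, 1.2-fold (0.09 log units) apart, within the scatter of two such steps. Neither change depends measurably on the core across these two cores, but every step lies within the scatter, so this shows agreement between small steps and no established effect of either change.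

On these data alone, it remains open whether an amine or a carboxylic acid on that aromatic carbon would give a step beyond the scatter. The same question stands for a longer alkyl chain on the sulfur.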